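Oral exposure notes on compounds 1 to 3

The source may report more compounds than this note shows. Statements on the series, on what has been measured and on what is new or still open speak of the compounds shown alone.

Measured compounds:
compound 1, `C=CC(=O)N1CC[C@H](N2C(=O)N(Cc3ccccc3)Cc3cnc(Nc4ccc(N5CCN(C)CC5)cc4OC)nc32)C1`: 418 ng.h/mL
compound 2, `C=CC(=O)N1CC[C@H](N2C(=O)N(c3ccccc3)Cc3cnc(Nc4cccc(N5CCN(C)CC5)c4)nc32)C1`: 760 ng.h/mL

Both values come from an ADME assay on the whole organism (plasma, strain Sprague-Dawley) for pharmacokinetics, with Rattus norvegicus as the target, read by LC-MS, at a dose of 25 mg/kg by the oral route; on this read-out lower numbers stand for lower exposure and higher numbers for higher exposure at the dose given. In this assay the numbers of compound 2 and compound 1 lie within the scatter of one another, so neither compound stands apart from the other, and compound 2 simply marks one end of a narrow pair of values. Compound 3, `C=CC(=O)N1CC[C@H](N2C(=O)N(c3ccccc3)Cc3cnc(Nc4ccccc4)nc32)C1`, is not yet measured in this assay. Its change from compound 2 is hydrogen in place of 4-methylpiperazin-1-yl on an aromatic carbon, in words hydrogen in place of 4-methylpiperazin-1-yl on an aromatic carbon. Within the data shown here, no pair of measured compounds differs in this place alone, so no measured step bears on the change; the two measured values show only the range covered so far. With no such reference the expected step is set at none beyond the scatter, with a wide band to either side, as a 1.3-fold lower number from compound 2 to compound 3 (0.10 log units; within the scatter). Compound 3 is accordingly estimated at 600 ng.h/mL in this assay, with a range from 150 ng.h/mL to 2400 ng.h/mL.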

Compound 3, area under the concentration-time curve: 4520 ng.h/mL
Beside the measured number, compound 3's estimate is 7.5-fold (0.88 log units) below it; measured number above the stated range.
By their numbers in this assay, from the lowest: compounds 1 and 2 (each within the scatter of the next); then compound 3.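

In this assay, among these compounds, the change of 4-methylpiperazin-1-yl to hydrogen gives a 5.9-fold higher number from compound 2 to compound 3 (0.77 log units; beyond the scatter), the first step that isolates this one place and the first that lies beyond the scatter. On this aromatic carbon of a six-membered aromatic ring of carbon only, the exposure at the dose given therefore does not depend on keeping the 4-methylpiperazin-1-yl group, and the compound without it stands clearly higher on this read-out; this rests on a single pair and holds for that pair alone. Nothing measured here bears on the reason for the step.

From the compounds shown here alone, it remains open whether a smaller or different group on this carbon, such as dimethylamino or morpholin-4-yl, would give a number closer to that of compound 2 or to that of compound 3, and so whether the whole ring or only part of it goes with the step. Going by these compounds, it is equally open whether the same change on the core of compound 1 would give a step of similar size.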